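The source may report more compounds than this note shows. Statements on the series, on what has been measured and on what is new or still open speak of the compounds shown alone.

Measured so far:
compound 1, `CC[C@@H]1C(=O)N(C)c2cnc(-n3ccnc3-c3ccccc3)nc2N1C1CCCC1` — 0%
compound 2, `CC(C)N1c2nc(-n3ccnc3-c3ccc(F)cc3)ncc2N(C)C(=O)C1(C)C` — 54%

Both compounds were examined in an ADME assay on microsomes from liver (Homo sapiens) for metabolic stability, with a stated time of 30 min, tested at 1 uM; on this read-out lower numbers stand for a less stable compound and higher numbers for a more stable compound. Compound 1 returns 0%, the lowest of the two numbers; compound 2 gives 54%, a higher number, and the gap between the two is beyond the usual scatter of such measurements. Within the data shown here, these two compounds differ in several places at once, so their two values show only that the shared core can be carried with widely different outcomes in this assay.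

The unmeasured compound 3, `CC[C@@H]1C(=O)N(C)c2cnc(-n3ccnc3-c3ccccc3)nc2N1CCC(F)(F)F`, departs from compound 1 in exactly one place: 3,3,3-trifluoropropyl in place of cyclopentyl on a nitrogen on an aromatic ring in a ring. Among the measured compounds shown here, no single-change step between measured compounds is available to calibrate this move, so any expectation rests on the structural change itself and on the floor set by compound 1.

For compound 3 a moderate rise in this assay is expected, as a step of a number 25 percentage points higher from compound 1 to compound 3 (beyond the scatter) upward from compound 1. The estimate for compound 3 in this assay is 25%, within a range of 5% to 55%.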

Compound 3, percent of the compound remaining: 0%
The estimate for compound 3 lay 25 percentage points above the measured number, and the stated range ends above it.
By their numbers in this assay, from the lowest: compounds 1 and 3 (each within the scatter of the next); then compound 2.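

In this assay, 3,3,3-trifluoropropyl in place of cyclopentyl on this nitrogen gives no change at the digits printed from compound 1 to compound 3 (within the scatter), the first single-change step available in this set. On the core of compound 1, exchanging a five-membered ring of carbon only for this open chain therefore does not lift the number off the bottom of the read-out, and with both compounds at the lowest value it can give, any difference in stability between them stays out of sight. Nothing available bears on why the number stays where it is.

The compounds shown leave open whether any other group on this nitrogen, such as a tetrahydropyranyl ring or a chain carrying an amine, can raise the number on the core of compound 1. They also leave open what a change at the ring atom that bears an ethyl group, such as a methoxy group in place of the ethyl group, would do to it.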